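A few compounds are considered here, and "the series" means these few. Any claim that something is new, unique, unknown or untested is made for them only; others in the source may bear on it.

Measured so far:
compound 1 `COc1cccc(Oc2ccc3c(NCCCNCc4cc(F)ccc4OC)ccnc3c2)c1`: 7100 nM
compound 2 `COc1cccc(Oc2ccc3c(NCCCNCc4ccco4)ccnc3c2)c1`: 15500 nM

In an ADME assay on HepG2 cells (Homo sapiens) for cytotoxicity, read by luminescence, CellTiter-Glo and ATP content, with a stated time of 72 h (on this read-out higher numbers stand for an effect only at larger amounts of compound and lower numbers for an effect already at smaller amounts), compound 1 gives 7100 nM, the lowest of the two numbers, while compound 2 gives 15500 nM. Among the compounds with values here, the only known step, a 2.2-fold higher number from compound 1 to compound 2 (0.34 log units; beyond the scatter), swapped the group on the chain carbon next to the amine nitrogen. Compound 3 `COc1ccc(-c2ccc3c(NCCCNCc4cc(F)ccc4OC)ccnc3c2)cc1` instead changes the aryl ether side: 4-methoxyphenyl in place of 3-methoxyphenoxy on an aromatic carbon. Within the data shown here, no measured step touches this part of the core, so the step is expected to stay within the scatter. Compound 3 is therefore estimated at 7000 nM, with a range of 2500 nM to 20000 nM, meaning a step of a 1.0-fold lower number from compound 1 to compound 3 (0.01 log units; within the scatter).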

Compound 3, half-maximal effective concentration: 5960 nM
For compound 3 the middle estimate is 1.2-fold (0.07 log units) above the measured one; low and high end bracket the measured number.
By their numbers in this assay, from the lowest: compounds 3 and 1 (each within the scatter of the next); then compound 2.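

In this assay, 4-methoxyphenyl in place of 3-methoxyphenoxy on this aromatic carbon of the shared core gives a 1.2-fold lower number from compound 1 to compound 3 (0.08 log units; within the scatter), so this exchange leaves no readable change in the number. Within the data shown here, the earlier pair changed only the other end of the molecule, so this is the first reading at this position. No measurement here offers an explanation for this result.

The exchange changes the group's oxygen count and the place of its methoxy together, and the compounds shown cannot separate the two. Going by these compounds, how an amine or a carboxylic acid on the ring would read also remains open.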